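Carbamate in place of acetyl on the piperazine series

The source may report more compounds than this note shows. Statements on the series, on what has been measured and on what is new or still open speak of the compounds shown alone.

Measured compounds:
compound 1 `CC(=O)N1CCN(c2nnc3nncn3n2)CC1`: 14700 nM
compound 2 `CN(C)c1nnc2nncn2n1`: 4840 nM
compound 3 `CCCNc1nnc2nncn2n1`: 15100 nM

In a functional assay on HL-60 cells (Homo sapiens) for inhibition, read by MTT assay, with a stated time of 72 h (on this read-out higher numbers stand for weaker inhibition and lower numbers for stronger inhibition), compound 1 gives 14700 nM. The value of compound 1 and that of compound 3 lie within the scatter of each other, while compound 2 gives a number below both that is beyond the scatter. Among the measured compounds shown here, the one single-point step among the measured compounds is a 3.1-fold higher number from compound 2 to compound 3 (0.49 log units; beyond the scatter); it sits on an aromatic carbon of the shared core, not on the carbonyl side chain, and so does not bear directly on the change considered here.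

Compound 4 `CC(C)COC(=O)N1CCN(c2nnc3nncn3n2)CC1` differs from compound 1 as follows: isobutoxy in place of methyl on a carbonyl carbon. For the measured compounds named here, no measured pair shows what altering the substituent on this carbonyl carbon does in this assay. Going by the values given here, with no step bearing on the change, the expectation for compound 4 is a number close to that of compound 1, with no step beyond the scatter, so a 1.1-fold lower number from compound 1 to compound 4 (0.05 log units; within the scatter). Compound 4 is therefore estimated at 13000 nM, within the range 5000 nM to 35000 nM.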

Compound 4, half-maximal inhibitory concentration: 7930 nM
The estimate for compound 4 lay 1.6-fold (0.21 log units) above the measured number; measured number inside the range.
By their numbers in this assay, from the lowest: compounds 2, 4, 1 and 3 (each within the scatter of the next, the first and the last beyond it).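

In this assay, among the compounds shown here, this is the first pair that speaks to the substituent on this carbonyl carbon: a 1.9-fold lower number from compound 1 to compound 4 (0.27 log units; within the scatter). Acetyl and isobutoxycarbonyl therefore cannot be told apart at this position in this single pair, and the exchange of methyl for isobutoxy does not carry the value beyond the scatter. No measured data explain this step.

Still open, from the compounds shown here alone, is whether other groups on this carbonyl carbon, such as methoxy, benzyloxy or a simple amine, would also stay within the scatter of compound 1 or would give a clear step in either direction. Also open, going by these compounds, is whether a longer alkoxy chain at the same carbon would keep the value of compound 4 in this range.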